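From 2-chlorophenyl to 4-fluorophenyl on the shared core

A few compounds are considered here, and "the series" means these few. Any claim that something is new, unique, unknown or untested is made for them only; others in the source may bear on it.

In an ADME assay on MT4 cells (Homo sapiens) for cytotoxicity, read by MTT assay, with a stated time of 96 h (on this read-out lower numbers stand for higher toxicity in this test and higher numbers for lower toxicity in this test), compound 1 (`NS(=O)(=O)c1ccc(N2N=C(c3ccc(Oc4ccccc4)cc3)CC2c2ccccc2)cc1`) gives 42000 nM. Going by the values given here, compound 2 (`NS(=O)(=O)c1ccc(N2N=C(c3ccc(Oc4ccccc4)cc3)CC2c2ccccc2Cl)cc1`) gives 40000 nM, which places it level with compound 1, the only other measured compound. Compound 3 (`NS(=O)(=O)c1ccc(N2N=C(c3ccc(Oc4ccccc4)cc3)CC2c2ccc(F)cc2)cc1`) has not yet been measured. It carries 4-fluorophenyl in place of 2-chlorophenyl on a saturated ring carbon.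

Among the compounds with values here, only one measured step bears on this change, and only in part. That step, a 1.1-fold lower number from compound 1 to compound 2 (0.02 log units; within the scatter), puts chloro in place of hydrogen on an aromatic carbon and stays within the scatter. Within the data shown here, no compound with a fluoro group has been measured. Starting from compound 2, no step beyond the scatter is therefore expected in this assay. The expected change is a 1.0-fold higher number from compound 2 to compound 3 (0.01 log units; within the scatter). Compound 3 is estimated at 41000 nM, with an expected range of 22000 nM to 75000 nM.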

Compound 3, half-maximal cytotoxic concentration: 33000 nM
Compound 3: middle estimate off by 1.2-fold (0.09 log units), on the high side; low and high end bracket the measured number.
By their numbers in this assay, from the lowest: compounds 3, 2 and 1 (each within the scatter of the next).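

In this assay, 4-fluorophenyl in place of 2-chlorophenyl on the saturated ring carbon gives a 1.2-fold lower number from compound 2 to compound 3 (0.08 log units; within the scatter), while adding a fluoro group to the unsubstituted phenyl group gives a 1.3-fold lower number from compound 1 to compound 3 (0.10 log units; within the scatter). The earlier pair had shown only that a chloro group leaves the number within the scatter; these steps show the same for a fluoro group and for a swap between two substituted phenyl groups at this position. No measurement shown here speaks to why the three compounds stay this close.

From the compounds shown here alone, whether an amine or a carboxylic acid on this phenyl group, or a cyclohexyl group in its place, would move the number beyond the scatter stays open. The three compounds also leave open how these same changes would read outside this assay.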